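The source may hold more compounds than are shown below. What is called first, only, known or untested is meant among the compounds shown, and "the series" means these compounds.

Compound 2, `CCOc1cccc(-c2ccc(CN(C(=O)C(C)C)c3cccc(/C=C/C(=O)OC)c3)cc2)c1`, is the weaker-looking of two entries in an assay on isolated protein with Bile acid receptor (Homo sapiens) as the target (on this read-out higher numbers stand for an effect only at larger amounts of compound and lower numbers for an effect already at smaller amounts), where compound 2 gives 173 nM. Its nearest neighbour is compound 1, `COC(=O)/C=C/c1cccc(N(Cc2ccc(/C=C/c3c(F)cccc3F)cc2)C(=O)C(C)C)c1`, which in this assay gives 108 nM; the difference between them, a 1.6-fold higher number from compound 1 to compound 2 (0.20 log units; within the scatter), lies within the usual scatter, so the two compounds cannot be told apart on these numbers.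

Compound 3, `COC(=O)/C=C/c1cccc(N(Cc2ccc(-c3cccc(Cl)c3)cc2)C(=O)C(C)C)c1`, is the next compound to be measured. It differs from compound 2 in one place: chloro in place of ethoxy on an aromatic carbon. Seen one bond further out, the change reads 3-ethoxyphenyl to 3-chlorophenyl, sitting on the six-membered aromatic ring of carbon only, meta to a large group.

Among the measured compounds shown here, only one measured step exists, and it concerns a different part of the molecule; it was small. For the measured compounds named here, nothing measured so far speaks to swapping the group at this position, so the expectation is a step of about a 1.2-fold higher number from compound 2 to compound 3 (0.06 log units; within the scatter), within the scatter, in no particular direction. Compound 3 is therefore estimated at 200 nM, with a range from 70 nM to 600 nM.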

Compound 3, half-maximal effective concentration: 77 nM
Compound 3: middle estimate off by 2.6-fold (0.41 log units), on the high side; the measured number falls inside the stated range.
By their numbers in this assay, from the lowest: compounds 3, 1 and 2 (each within the scatter of the next, the first and the last beyond it).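

Among the compounds shown here, this is the first measured change at this place on the outer ring, and in this assay the swap of ethoxy for chloro gives a 2.2-fold lower number from compound 2 to compound 3 (0.35 log units; beyond the scatter). The step is modest, but it shows that the group held here can move the read-out beyond the scatter, with the single-atom chloro, which has no hydrogen-bond acceptor, giving the lower number of the pair. The other new comparison, replacing the 2-(2,6-difluorophenyl)ethenyl group with 3-chlorophenyl, gives a 1.4-fold lower number from compound 1 to compound 3 (0.15 log units; within the scatter), so those two compounds cannot be told apart, and nothing given here accounts for either step.

On these data alone, one pair cannot separate the effect of having chloro at this place from the effect of losing ethoxy, so it remains open whether a methyl, a methoxy or a bromo group would fall closer to chloro or to ethoxy. As far as these compounds go, it is also open how a nitrile, an amine or a carboxylic acid would behave here, and whether the same swap would give a similar step with the group placed elsewhere on that ring.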